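From butyl to nitro on a shared core

The source may hold more compounds than are shown below. What is called first, only, known or untested is meant among the compounds shown, and "the series" means these compounds.

Measured so far in an assay on membranes from brain for displacement of a labelled ligand from Neuronal acetylcholine receptor; alpha4/beta2 (Rattus norvegicus); a lower number here means a stronger inhibitor, a higher number a weaker inhibitor:
compound 1, `CN1CCC[C@H]1COc1cccnc1`, gives 0.15 nM
compound 2, `CN1CCC[C@H]1COc1cncc(Br)c1`, gives 0.27 nM
compound 3, `CCCCc1cncc(OC[C@@H]2CCCN2C)c1`, gives 0.16 nM

Compound 3 holds the second highest of the three numbers. Its nearest neighbour is compound 1, with a 1.1-fold higher number from compound 1 to compound 3 (0.03 log units; within the scatter), and its furthest is compound 2, with a 1.7-fold lower number from compound 2 to compound 3 (0.23 log units; within the scatter); both steps sit inside the usual scatter, so the three compounds cannot be told apart on these numbers.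

Compound 4, `CN1CCC[C@H]1COc1cncc([N+](=O)[O-])c1`, is not yet measured. It differs from compound 3 by nitro in place of butyl on an aromatic carbon.

Among the measured compounds shown here, three measured steps bear on this change, since all of them alter the same aromatic carbon. a 1.8-fold higher number from compound 1 to compound 2 (0.26 log units; within the scatter), a 1.1-fold higher number from compound 1 to compound 3 (0.03 log units; within the scatter) and a 1.7-fold lower number from compound 2 to compound 3 (0.23 log units; within the scatter) all stay within the scatter, whether the group present there is hydrogen, bromo or butyl. On that basis compound 4 is expected to land close to the others, with a step of a 1.9-fold higher number from compound 3 to compound 4 (0.27 log units; within the scatter) in this assay, not clearly beyond the scatter in either direction. The estimate for compound 4 is therefore 0.3 nM, with a range from 0.1 nM to 1 nM.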

Compound 4, inhibition constant: 4.65 nM
The estimate for compound 4 lay 16-fold (1.19 log units) below the measured number, and the stated range ends below it.
By their numbers in this assay, from the lowest: compounds 1, 3 and 2 (each within the scatter of the next); then compound 4.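

In this assay the aromatic carbon two atoms from the ring nitrogen proves sensitive to the group it carries: nitro gives a 29-fold higher number from compound 3 to compound 4 (1.46 log units; beyond the scatter) and a 17-fold higher number from compound 2 to compound 4 (1.24 log units; beyond the scatter) and a 31-fold higher number from compound 1 to compound 4 (1.49 log units; beyond the scatter) and so separates compound 4 from the other three compounds, all of these steps lying beyond the scatter. The earlier tolerance at this position therefore covers hydrogen, bromo and butyl but does not extend to every group, and heavy-atom count does not sort the result, since butyl has more heavy atoms than nitro and yet stays with hydrogen and bromo. The change also replaces a group with no hydrogen-bond acceptors by one with 2, but nothing available establishes why nitro stands apart.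

With only one group on the weak side, the compounds shown cannot tell whether this loss of binding is peculiar to nitro or would also appear with a nitrile, an amine or a carboxylic acid at the same carbon. They also leave open whether a chain longer than butyl would remain with compounds 1, 2 and 3 or move toward compound 4.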